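The compounds below may be only part of what the source reports. "The series", "measured", "known", "first", "only" and "open" are said of these compounds alone.

Three compounds share one core, and each ends in a five-membered ring with three nitrogens that carries a different aromatic group. Compound 1 `N#CC1=C(N)Oc2c(c3nc4ccccc4nc3c3ccccc23)C12C(=O)N(Cc1cnnn1-c1cccc(Br)c1)c1ccccc12` reaches only the limit of a functional assay on A549 cells (Homo sapiens) for antiproliferative activity, read by MTT assay, with a stated time of 48 h; a higher number here means a weaker inhibitor, a lower number a stronger inhibitor: compound 1 gives > 50000 nM, which is a limit and not a number. Compound 2 `CCOc1ccccc1-n1nncc1CN1C(=O)C2(C(C#N)=C(N)Oc3c2c2nc4ccccc4nc2c2ccccc32)c2ccccc21` likewise gives > 50000 nM in this assay, again a limit. Compound 3 `N#CC1=C(N)Oc2c(c3nc4ccccc4nc3c3ccccc23)C12C(=O)N(Cc1cnnn1-c1cccc(S(N)(=O)=O)c1)c1ccccc12` is the one of the three whose result is a number: in this assay compound 3 gives 44200 nM. Because of the limit of > 50000 nM in this assay, at which 2 of the 3 values shown sit, the steps toward it can only be given as floors: an at least 1.1-fold lower number from compound 1 to compound 3 (0.05 log units; that floor lies within the scatter), and an at least 1.1-fold lower number from compound 2 to compound 3 (0.05 log units; that floor lies within the scatter). Between compound 1 and compound 2 there is a step that the two limits leave unreadable from compound 1 to compound 2.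

Compound 4 `N#CC1=C(N)Oc2c(c3nc4ccccc4nc3c3ccccc23)C12C(=O)N(Cc1cnnn1-c1ccc(F)c(Cl)c1)c1ccccc12` differs from compound 3 by 3-chloro-4-fluorophenyl in place of 3-sulfamoylphenyl on an aromatic nitrogen. Among the compounds with values here, the steps that bear on this change, from compound 1 to compound 3 and from compound 2 to compound 3, have floors that sit within the scatter, so they show no readable shift in either direction. Compound 1, which also carries a halogen on its aromatic group, gives > 50000 nM, a limit. The step from compound 3 to compound 4 is therefore expected to be a 1.4-fold higher number from compound 3 to compound 4 (0.13 log units; within the scatter), with a fair chance that only a limit is returned. Compound 4 is estimated at 60000 nM, within 30000 nM to 150000 nM.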

Compound 4, half-maximal inhibitory concentration: > 50000 nM
Compound 4 was reported as a limit; the forecaster's own chance of this, stated with the estimate: 65%; the middle value does not contradict the limit.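

Within the data shown here, compound 4 shows that a second halogen-bearing group on this aromatic nitrogen, now with both chlorine and fluorine on the ring, also ends at a limit and not at a number in this assay, as the single bromine of compound 1 did. Among these compounds, removing the 3-sulfamoylphenyl group, the only group here that returns a number, gives an at least 1.1-fold higher number from compound 3 to compound 4 (0.05 log units; that floor lies within the scatter), so these results do not show that the sulfamoyl group makes a real difference. The steps among compound 1, compound 2 and compound 4 cannot be read, because all three stop at the same limit: the limit of > 50000 nM in this assay, at which 3 of the 4 values shown sit.

The compounds shown leave open whether any group at this position can give a number clearly lower than that of compound 3, at 44200 nM, for example a phenyl ring carrying a carboxylic acid or a dimethylamino group, or a short alkyl chain in place of the ring. They also leave open whether the activity depends on this position at all, since every compound shown keeps the shared core unchanged.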